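A few compounds are considered here, and "the series" means these few. Any claim that something is new, unique, unknown or untested is made for them only; others in the source may bear on it.

Compound 1 `C[C@H](Oc1ccc(S(C)(=O)=O)cc1C(=O)N1Cc2cnc(C(F)(F)F)cc2C1)C(F)(F)F`: 132 nM
Compound 2 `CC(C)COc1ccc(S(C)(=O)=O)cc1C(=O)N1Cc2cc(C(F)(F)F)cnc2C1`: 30 nM

Both compounds were measured in an assay on CHO cells for inhibition of sodium- and chloride-dependent glycine transporter 1 (Homo sapiens), read by scintillation counting; on this read-out higher numbers stand for an effect only at larger amounts of compound and lower numbers for an effect already at smaller amounts. Compound 2 gives the lower of the two numbers; the nearest is compound 1, whose number is higher by a margin that lies beyond the usual scatter of repeated measurements. Compound 3 `CS(=O)(=O)c1ccc(-c2ccc(F)c(F)c2)c(C(=O)N2Cc3cc(C(F)(F)F)cnc3C2)c1` is not yet measured and differs from compound 2 in one place: 3,4-difluorophenyl in place of isobutoxy on an aromatic carbon. Within the data shown here, no two measured compounds differ only in this way, so nothing measured here shows what this exchange does. The expectation for compound 3 is therefore loose: a shift in this assay that may well stay within the scatter, with a somewhat higher number being the more likely direction. The step from compound 2 to compound 3 is expected to be a 2.0-fold higher number from compound 2 to compound 3 (0.30 log units; within the scatter). Compound 3 is estimated at 60 nM, within a range from 15 nM to 250 nM.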

Compound 3, half-maximal effective concentration: 30 nM
Compound 3: middle estimate off by 2.0-fold (0.30 log units), on the high side, within the range that was stated.
By their numbers in this assay, from the lowest: compounds 2 and 3 (each within the scatter of the next); then compound 1.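

In this assay, putting 3,4-difluorophenyl in place of isobutoxy on the aromatic carbon para to the methylsulfonyl group gives no change at the digits printed from compound 2 to compound 3 (within the scatter) as the step. This position, ortho to a large group, therefore accepts either an open chain with one oxygen or a six-membered aromatic ring of carbon only, with 8 heavy atoms in place of 5, and the hydrogen-bond acceptor of isobutoxy is not required to keep the number in this pair. No measurement here explains why two such different groups give matching numbers.

Still open is whether the two fluorines matter, since an unsubstituted phenyl ring is not among the compounds shown. As far as these compounds go, it is also open how a group of another kind, such as an amine or a longer chain, would behave at this position.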